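This account rests on a few compounds, and the source may have more. Where it says the series, first, only, none or still open, it means among the compounds named here.

Measured in a functional assay on COLO 205 cells (Homo sapiens) for inhibition, read by sulforhodamine B assay, with a stated time of 48 h, tested at 50 uM; a higher number here means more inhibition of growth at the concentration tested, a lower number less inhibition of growth:

compound 1 `COc1cc(/C=C/C(=O)/C=C/c2cccc3ccccc23)ccc1OCc1cn(CCCOc2cc(=O)oc3ccccc23)nn1` gives 64%
compound 2 `COc1ccccc1/C=C/C(=O)/C=C/c1ccc(OCc2cn(CCCOc3cc(=O)oc4ccccc34)nn2)c(OC)c1` gives 57%
compound 3 `COc1cccc(/C=C/C(=O)/C=C/c2ccc(OCc3cn(CCCOc4cc(=O)oc5ccccc45)nn3)c(OC)c2)c1` gives 52%

These three compounds differ only in the aromatic group at one end of the molecule. Two steps fix the place of compound 3 among them. One is a number 12 percentage points lower from compound 1 to compound 3 (beyond the scatter), which separates it from compound 1. The other is a number 5 percentage points lower from compound 2 to compound 3 (within the scatter), which leaves it level with compound 2.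

The next compound, compound 4 `COc1ccc(/C=C/C(=O)/C=C/c2ccc(OCc3cn(CCCOc4cc(=O)oc5ccccc45)nn3)c(OC)c2)cc1OC`, carries one change at that same end methoxy in place of hydrogen on an aromatic carbon, so that 3-methoxyphenyl becomes 3,4-dimethoxyphenyl. Among the compounds with values here, no measured pair shows this exact addition, so the evidence is indirect. Within the data shown here, the swap of naphthalen-1-yl for 2-methoxyphenyl gave a number 7 percentage points lower from compound 1 to compound 2 (within the scatter), and the only step past the scatter also replaced the naphthalen-1-yl group. Exchanging one methoxyphenyl group for the other, the closest comparison, gave a number 5 percentage points lower from compound 2 to compound 3 (within the scatter). On these data alone, on that basis, no change beyond the scatter is expected in this assay, and the direction remains open. The expected step is a number 2 percentage points higher from compound 3 to compound 4 (within the scatter). For compound 4 the estimated value is 54%, with an expected range from 42% to 66%.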

Compound 4, percent growth inhibition at one concentration: 65%
Compound 4: middle estimate off by 11 percentage points, on the low side; the range from low to high includes it.
By their numbers in this assay, from the lowest: compounds 3, 2, 1 and 4 (each within the scatter of the next, the first and the last beyond it).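

In this assay, the added methoxy group, ortho to a methoxy group and para to a large group, gives a number 13 percentage points higher from compound 3 to compound 4 (beyond the scatter). Within the data shown here, this is the first step beyond the scatter that comes from adding a small group to a phenyl ring, whereas the earlier step of that size came from replacing the whole naphthalen-1-yl group. The 3,4-dimethoxyphenyl end also stands level with the other two end groups, with a number 8 percentage points higher from compound 2 to compound 4 (within the scatter) and a number 1 percentage points higher from compound 1 to compound 4 (within the scatter), so on this read-out a phenyl ring with two methoxy groups matches the two-ring naphthalen-1-yl group, and nothing available explains the effect of the added methoxy group.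

On these data alone, it remains open whether the second methoxy group works only alongside the first, or whether a methoxy group at this place would give the same step on its own. As far as these compounds go, it is also open whether a hydroxy group, an amine or a carboxylic acid at this same carbon would give a step of similar size, or a different one.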